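The source may report more compounds than this note shows. Statements on the series, on what has been measured and on what is new or still open speak of the compounds shown alone.

Among the measured compounds shown here, in a functional assay on HeLa cells (Homo sapiens) for inhibition, read by cell counting, with a stated time of 4 days (on this read-out higher numbers stand for weaker inhibition and lower numbers for stronger inhibition), compound 3 `C=C(Br)C(=O)Nc1cccc(-c2cn3nc(-c4cccs4)sc3n2)c1` gives 670 nM, the lowest of the three numbers measured so far, though the step of a 1.3-fold lower number from compound 1 to compound 3 (0.11 log units; within the scatter) lies within the scatter, so compound 1 `C=C(Br)C(=O)Nc1cccc(-c2cn3nc(-c4ccc(F)cc4)sc3n2)c1` with its 870 nM cannot be set apart from it. Compound 2 `C=C(Br)C(=O)Nc1cccc(-c2cn3nc(Cc4ccccc4)sc3n2)c1` gives 4500 nM, and the step of a 6.7-fold lower number from compound 2 to compound 3 (0.83 log units; beyond the scatter) is the one clear movement in the set, matched by the step of a 5.2-fold higher number from compound 1 to compound 2 (0.71 log units; beyond the scatter) on the other side.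

Compound 4 `C=C(Br)C(=O)Nc1cccc(-c2cn3nc(-c4ccc(OC)cc4)sc3n2)c1` has not yet been measured. It differs from compound 3 by 4-methoxyphenyl in place of thiophen-2-yl on an aromatic carbon. The measured step that bears most directly on this exchange is the one between a 4-fluorophenyl and a thiophen-2-yl at the same carbon, a 1.3-fold lower number from compound 1 to compound 3 (0.11 log units; within the scatter), which stayed within the scatter; the two steps involving benzyl are the only ones beyond it, and neither concerns a six-membered aromatic ring of carbon only. On that basis the return to a six-membered aromatic ring of carbon only, now carrying a methoxy group, is expected to change the number in this assay by no more than the scatter, so the expected step is a 1.3-fold higher number from compound 3 to compound 4 (0.13 log units; within the scatter). Compound 4 is therefore estimated at 900 nM, with a range from 400 nM to 2500 nM.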

Compound 4, half-maximal inhibitory concentration: 2300 nM
Compound 4: the middle estimate sits 2.6-fold (0.41 log units) below what was measured, within the range that was stated.
By their numbers in this assay, from the lowest: compounds 3 and 1 (each within the scatter of the next); then compounds 4 and 2 (each within the scatter of the next).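

In this assay, the step of a 2.6-fold higher number from compound 1 to compound 4 (0.42 log units; beyond the scatter) shows that this aromatic carbon responds to more than the kind of ring placed on it: methoxy in place of fluoro on the phenyl ring, with the rest of the structure unchanged, moves the number beyond the scatter. The step of a 3.4-fold higher number from compound 3 to compound 4 (0.54 log units; beyond the scatter) also lies beyond the scatter, so a six-membered aromatic ring of carbon only does not in itself keep the number level with that of the thiophen-2-yl compound: the 4-fluorophenyl group of compound 1 does so, while the 4-methoxyphenyl group of compound 4 does not. With a 2.0-fold lower number from compound 2 to compound 4 (0.29 log units; within the scatter) inside the scatter, compound 4 cannot be set apart from compound 2, so benzyl no longer stands alone among the groups giving the higher numbers at this carbon.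

From the compounds shown here alone, whether a 4-chlorophenyl, 4-hydroxyphenyl or 4-aminophenyl group at this carbon would fall with compound 1 or with compound 4 remains open. Nothing shown here explains why the methoxy and fluoro compounds differ.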